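Moving the Trifluoromethyl Group Around the Hydrazone Ring

A few compounds are considered here, and "the series" means these few. Any claim that something is new, unique, unknown or untested is made for them only; others in the source may bear on it.

Of the compounds shown here, three sharing one core have been tested in a functional assay on HeLa cells (Homo sapiens) for inhibition, read by MTT assay, with a stated time of 72 h; on this read-out lower numbers stand for stronger inhibition and higher numbers for weaker inhibition. Compound 1 `CN(C(=O)NC(=O)c1ccc(F)c(F)c1)c1nc(C(F)(F)F)c(C(=O)N/N=C/c2cccc(C(F)(F)F)c2)s1` gives 4.21 ug/mL, and compound 2 `CN(C(=O)NC(=O)c1ccc([N+](=O)[O-])cc1)c1nc(C(F)(F)F)c(C(=O)N/N=C/c2cccc(C(F)(F)F)c2)s1` gives 4.12 ug/mL; the step of a 1.0-fold lower number from compound 1 to compound 2 (0.01 log units; within the scatter) shows that swapping the aryl group on the carbonyl carbon changed little. Compound 3 `CN(C(=O)NC(=O)c1ccccc1F)c1nc(C(F)(F)F)c(C(=O)N/N=C/c2ccccc2C(F)(F)F)s1` gives 10.1 ug/mL, the highest of the three numbers, beyond the scatter from both compound 1 and compound 2.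

Compound 4 `CN(C(=O)NC(=O)c1ccccc1F)c1nc(C(F)(F)F)c(C(=O)N/N=C/c2cccc(C(F)(F)F)c2)s1` differs from compound 3 by one change: 3-(trifluoromethyl)phenyl in place of 2-(trifluoromethyl)phenyl on a carbon with a double bond to nitrogen. Going by the values given here, no measured step isolates this change; compounds 1 and 2 carry the same 3-(trifluoromethyl)phenyl as compound 4 but also a different aryl on the carbonyl carbon, so their gap to compound 3 mixes two changes. Among the compounds with values here, the only measured step, from compound 1 to compound 2, touched the other aryl and stayed within the scatter.

Compound 4 is therefore expected to land somewhat lower than compound 3, an estimated step of a 1.7-fold lower number from compound 3 to compound 4 (0.23 log units; within the scatter) in this assay . The estimate for compound 4 is 6 ug/mL, within a range from 2.5 ug/mL to 14 ug/mL.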

Compound 4, half-maximal inhibitory concentration: 19.1 ug/mL
Compound 4: the middle estimate sits 3.2-fold (0.50 log units) below what was measured, outside the stated range (above it).
By their numbers in this assay, from the lowest: compounds 2 and 1 (each within the scatter of the next); then compounds 3 and 4 (each within the scatter of the next).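

With 2-fluorophenyl held on the carbonyl carbon, 3-(trifluoromethyl)phenyl in place of 2-(trifluoromethyl)phenyl gives a 1.9-fold higher number from compound 3 to compound 4 (0.28 log units; within the scatter) in this assay and so cannot be told apart from repeat-measurement noise. The aryl on the carbonyl carbon, which made no readable difference between compound 1 and compound 2, now does: with 3-(trifluoromethyl)phenyl held, 2-fluorophenyl in place of 4-nitrophenyl gives a 4.6-fold higher number from compound 2 to compound 4 (0.67 log units; beyond the scatter) and 2-fluorophenyl in place of 3,4-difluorophenyl gives a 4.5-fold higher number from compound 1 to compound 4 (0.66 log units; beyond the scatter) in this assay. No measurement on hand explains these gaps.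

Open, going by these compounds, is whether a plain phenyl, or a phenyl carrying an amine or a carboxylic acid instead of trifluoromethyl, would shift the number at the carbon with a double bond to nitrogen. Also open, on these data alone, is whether the swap of trifluoromethyl-bearing rings stays this small with 4-nitrophenyl or 3,4-difluorophenyl on the carbonyl carbon.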